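The source may hold more compounds than are shown below. What is called first, only, known or untested is meant among the compounds shown, and "the series" means these compounds.

Measured compounds:
Compound 1 `CC(C)c1ccc(-c2nc(SCc3cn(CC(=O)NC(=O)Nc4ccccn4)nn3)nc(Nc3ccccc3F)c2C#N)cc1`: 15500 nM
Compound 2 `Cc1cccc(Nc2nc(SCc3cn(CC(=O)NC(=O)Nc4ccccn4)nn3)nc(-c3ccc(C(C)C)cc3)c2C#N)c1`: 7320 nM

Within the data shown here, in a functional assay on ECa-109 cells (Homo sapiens) for inhibition, read by MTT assay, with a stated time of 72 h (on this read-out higher numbers stand for weaker inhibition and lower numbers for stronger inhibition), compound 2 gives the lower of the two numbers so far, with compound 1 the nearest neighbour. Among the measured compounds shown here, the one measured step, a 2.1-fold lower number from compound 1 to compound 2 (0.33 log units; beyond the scatter), shows a modest gain when 3-methylphenyl replaces 2-fluorophenyl on the nitrogen on the aromatic ring.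

Compound 3 `CC(C)c1ccc(-c2nc(SCc3cn(CC(=O)NC(=O)Nc4ccccn4)nn3)nc(Nc3ccccc3O)c2C#N)cc1` is not yet measured. It differs from compound 2 by 2-hydroxyphenyl in place of 3-methylphenyl on a nitrogen on an aromatic ring. The step from compound 1 to compound 2 bears on this only loosely: compound 1 carries 2-fluorophenyl at this nitrogen and gives the higher number, so a return to a 2-substituted phenyl, now 2-hydroxyphenyl, is expected to move the number back upward. A step of about a 1.6-fold higher number from compound 2 to compound 3 (0.21 log units; within the scatter) is therefore expected, within the spread seen between compound 1 and compound 2. Compound 3 is estimated at 12000 nM, in the range 5000 nM to 30000 nM.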

Compound 3, half-maximal inhibitory concentration: 7380 nM
Estimate against measurement, compound 3: 1.6-fold (0.21 log units) above; measured number inside the range.
By their numbers in this assay, from the lowest: compounds 2 and 3 (each within the scatter of the next); then compound 1.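

In this assay, the step of a 1.0-fold higher number from compound 2 to compound 3 (0.00 log units; within the scatter) shows that 2-hydroxyphenyl and 3-methylphenyl on this nitrogen cannot be told apart, even though 2-hydroxyphenyl brings a hydrogen-bond donor and acceptor that 3-methylphenyl lacks. The step of a 2.1-fold lower number from compound 1 to compound 3 (0.32 log units; beyond the scatter), made by hydroxy in place of fluoro on an aromatic carbon, shows that the higher number of compound 1 does not extend to every 2-substituted phenyl here, but depends on which group is present. No measurement at hand explains either result.

From the compounds shown here alone, it remains open whether an amine or a methoxy group on that aromatic carbon would stay with compound 3 or move towards compound 1. The compounds shown also leave open how an unsubstituted phenyl on this nitrogen would compare.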